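Extending the Amide of Compound 2 to a Urea

The compounds below may be only part of what the source reports. "The series", "measured", "known", "first", "only" and "open" are said of these compounds alone.

In a functional assay on SF-539 cells (Homo sapiens) for inhibition, read by sulforhodamine B assay, with a stated time of 48 h (a higher number here means a weaker inhibitor of growth, a lower number a stronger inhibitor of growth), compound 1 (`O=C(Nc1cccc(-n2cc(-c3ccncc3)c(-c3ccc(Cl)c(O)c3)n2)c1)Nc1cccc(C(F)(F)F)c1`) gives 3540 nM, while compound 2 (`COc1cc(-c2nn(-c3cccc(NC(=O)c4cccc(C(F)(F)F)c4)c3)cc2-c2ccncc2)ccc1Cl`) gives 895 nM. Compound 2 thus holds the lower of the two numbers, and the gap lies beyond the usual scatter. Compound 3 (`COc1cc(-c2nn(-c3cccc(NC(=O)Nc4ccc(Cl)c(C(F)(F)F)c4)c3)cc2-c2ccncc2)ccc1Cl`) departs from compound 2 in one place: on a carbonyl carbon, (4-chloro-3-(trifluoromethyl)phenyl)amino stands in place of 3-(trifluoromethyl)phenyl ((4-chloro-3-(trifluoromethyl)phenyl)amino in place of 3-(trifluoromethyl)phenyl on a carbonyl carbon). Among the measured compounds shown here, the measured compounds offer no step that isolates this change. Compound 1 at 3540 nM differs from compound 2 in more than one place, so that gap sets no direction for it. In this assay, no change beyond the scatter is therefore expected. The expected step is a 1.4-fold lower number from compound 2 to compound 3 (0.14 log units; within the scatter), with only a slight lean towards a lower number. Compound 3 is estimated at 650 nM, with an expected range of 180 nM to 2400 nM.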

Compound 3, concentration for 50% growth inhibition: 1650 nM
Estimate against measurement, compound 3: 2.5-fold (0.40 log units) below; the range from low to high includes it.
By their numbers in this assay, from the lowest: compounds 2 and 3 (each within the scatter of the next); then compound 1.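

In this assay, the first step read at this position, on the carbonyl carbon, gives a 1.8-fold higher number from compound 2 to compound 3 (0.27 log units; within the scatter). The swap of 3-(trifluoromethyl)phenyl for (4-chloro-3-(trifluoromethyl)phenyl)amino turns the amide into a urea, adding a hydrogen-bond donor and a chlorine, yet the two compounds cannot be told apart in this assay, so the position tolerates this larger group without a loss that can be read. Nothing measured here offers a reason for this outcome.

As far as these compounds go, the step brings in the amino nitrogen and the chlorine together, so what each does alone remains unknown. Also open, from the compounds shown here alone, is how a methyl group or a morpholine would fare in place of that chlorine, and whether either would move the number beyond the scatter.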